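The source may hold more compounds than are shown below. What is called first, only, known or untested is meant among the compounds shown, and "the series" means these compounds.

Measured so far:
Compound 1, `CC(C)N(Cc1cccc(OCCCCCC(=O)O)c1)C(=O)c1ccc(-c2ccsc2)cc1`: in an ADME assay on BJ cells (Homo sapiens) for cytotoxicity, read by CellTiter-Glo and resazurin assay, with a stated time of 72 h (a lower number here means that less compound is needed, a higher number that more compound is needed for the effect), compound 1 reaches only a limit, > 26000 nM.
Compound 2, `CCOc1cccc(-c2ccc(C(=O)N(Cc3cccc(OCCCCCC(=O)O)c3)C(C)C)cc2)c1`: in this assay compound 2 reaches only a limit, > 20800 nM.

Among the measured compounds shown here, compound 2 thus stands at a limit in this assay, and the one other value shown, that of compound 1, is a limit as well, so neither can be placed relative to the other. Compound 3, `CC(C)N(Cc1cccc(OCCCCCC(=O)O)c1)C(=O)c1ccc(-c2cccc(Cl)c2)cc1`, differs from compound 2 by chloro in place of ethoxy on an aromatic carbon. For the measured compounds named here, the only measured step, a step that the two limits leave unreadable from compound 1 to compound 2, cannot be read, as both of its ends sit at limits, the limit of > 20800 nM in this assay, at which 1 of the 2 values shown sits, and (the limit of > 26000 nM in this assay, at which 1 of the 2 values shown sits). No readable step bears on the change, and no step beyond the scatter is expected in either direction. Compound 3 is expected to give 30000 nM in this assay, with a range from 10000 nM to 100000 nM. This amounts to an expected step that the limit leaves unreadable from compound 2 to compound 3, most likely again reported only as a limit.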

Compound 3, half-maximal effective concentration: > 21900 nM
Compound 3: no number, only a limit (the forecaster's own chance of this, stated with the estimate: 85%); the middle value does not contradict the limit.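

In this assay compound 3 reaches only the limit > 21900 nM and no number. Compound 1 and compound 2 also stand at limits, so no step among these three compounds can be read. The compounds shown leave open at what concentration, if any, each would reach the half-maximal effect.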